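Swapping a vinyl for a chloromethyl on two amides

The source may report more compounds than this note shows. Statements on the series, on what has been measured and on what is new or still open speak of the compounds shown alone.

In a functional assay on Maver1 cells (Homo sapiens) for inhibition, read by luminescence and CellTiter-Glo, with a stated time of 72 h (a lower number here means a stronger inhibitor, a higher number a weaker inhibitor), a small set of compounds sharing one core is compared. Compound 1 `C=CC(=O)N1CCCC(n2nc(-c3ccc(Oc4ccccc4)cc3)cc2C(=O)OCC)C1` reaches only the limit of the assay, > 60000 nM. Compound 3 `CCOC(=O)c1cc(-c2ccc(Oc3ccccc3)cc2)nn1C1CCCN(C(=O)CCl)C1` gives 1200 nM. These two differ in a single place: chloromethyl in place of vinyl on a carbonyl carbon. That change produced an at least 50-fold lower number from compound 1 to compound 3 (1.69 log units; beyond the scatter), and the step can be given only as a lower bound because compound 1 sits at the limit of > 60000 nM in this assay, at which 1 of the 3 values shown sits. Among the measured compounds shown here, compound 2 `C=CC(=O)Nc1cccc(Cn2nc(-c3ccc(Oc4ccccc4)cc3)cc2CO)c1` gives 6700 nM, the higher of the two numbers measured so far, with compound 3 as its nearest neighbour. The difference between the core of compound 2 and the core of compound 1 is not broken down here.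

Compound 4 `O=C(CCl)Nc1cccc(Cn2nc(-c3ccc(Oc4ccccc4)cc3)cc2CO)c1` has not yet been measured. It stands to compound 2 as compound 3 stands to compound 1: chloromethyl in place of vinyl on a carbonyl carbon. The surroundings are not identical, though. In compound 1 the carbonyl carbon is attached to an amide-type nitrogen in a ring, whereas in compound 2 it is attached to an amide-type nitrogen that is not in a ring, so this is the same kind of change rather than the same change. For the measured compounds named here, since the one measured example of it, an at least 50-fold lower number from compound 1 to compound 3 (1.69 log units; beyond the scatter), was large, a lower number is expected for compound 4 too, though a more modest one given the different surroundings and cores. Compound 4 is therefore estimated at about 1500 nM, expected to fall between 300 nM and 6000 nM. That amounts to an expected 4.5-fold lower number from compound 2 to compound 4 (0.65 log units; beyond the scatter).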

Compound 4, half-maximal inhibitory concentration: 400 nM
For compound 4 the middle estimate is 3.8-fold (0.57 log units) above the measured one; the measured number falls inside the stated range.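

In this assay the second example of this change points the same way as the first: chloromethyl in place of vinyl on a carbonyl carbon gives a 17-fold lower number from compound 2 to compound 4 (1.22 log units; beyond the scatter), so on these two cores the swap lowers the number strongly both times. The direction carries over, but the size does not carry over unchanged, and two cores are too few to make a rule for the whole series: the same change on two cores in this assay, an at least 50-fold lower number (1.69 log units; beyond the scatter) from compound 1 to compound 3 and a 17-fold lower number (1.22 log units; beyond the scatter) from compound 2 to compound 4, at least 2.9-fold (0.47 log units) apart, beyond the scatter of two such steps. Compound 1 stands at a limit rather than at a true number, so the first step is only a lower bound and the real gap between the two steps may be wider: the limit of > 60000 nM in this assay, at which 1 of the 4 values shown sits.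

The compounds shown leave open what sets the size of the step, since the two cores differ in more than one place and nothing here separates those differences. They also leave open whether another group on the same carbonyl carbon, such as bromomethyl or a longer chain, would follow chloromethyl, and whether the swap would hold on a core carrying an amine or a carboxylic acid.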